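From Methyl to Ethoxy on a Methylated Analogue

The source may report more compounds than this note shows. Statements on the series, on what has been measured and on what is new or still open speak of the compounds shown alone.

In a functional assay on Jurkat cells (Homo sapiens) for antiproliferative activity, read by MTT assay, with a stated time of 72 h (on this read-out higher numbers stand for weaker inhibition and lower numbers for stronger inhibition), compound 3 `COc1cc(C(=O)c2sc3cc(C)ccc3c2Nc2ccc(C)cc2)cc(OC)c1OC` gives 2500 nM and so stands within the scatter of compound 1 `COc1cc(C(=O)c2sc3ccccc3c2Nc2ccc(C)cc2)cc(OC)c1OC` at 1700 nM while compound 2 `CCOc1ccc(Nc2c(C(=O)c3cc(OC)c(OC)c(OC)c3)sc3ccccc23)cc1` gives a clearly lower 300 nM on this scale. Compound 4 `CCOc1ccc(Nc2c(C(=O)c3cc(OC)c(OC)c(OC)c3)sc3cc(C)ccc23)cc1` differs from compound 3 by ethoxy in place of methyl on an aromatic carbon with ethoxy in place of methyl on an aromatic carbon, para to a large group. For the measured compounds named here, the same exchange gave a 5.7-fold lower number from compound 1 to compound 2 (0.75 log units; beyond the scatter) and is the only direct precedent. Methyl in place of hydrogen gave just a 1.5-fold higher number from compound 1 to compound 3 (0.17 log units; within the scatter) for the pair that links the two series. A similar drop is therefore expected, giving an estimated 5.6-fold lower number from compound 3 to compound 4 (0.74 log units; beyond the scatter) in this comparison. For compound 4 the estimated value is 450 nM with 150 nM to 1300 nM as the expected range.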

Compound 4, half-maximal inhibitory concentration: 5000 nM
The estimate for compound 4 lay 11-fold (1.05 log units) below the measured number, and the stated range ends below it.
By their numbers in this assay, from the lowest: compound 2; then compounds 1, 3 and 4 (each within the scatter of the next, the first and the last beyond it).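

In this assay the exchange of 4-methylphenyl for 4-ethoxyphenyl proved to depend on the core, giving a 2.0-fold higher number from compound 3 to compound 4 (0.30 log units; within the scatter) on the methylated core: the same change on two cores in this assay, a 5.7-fold lower number (0.75 log units; beyond the scatter) from compound 1 to compound 2 and a 2.0-fold higher number (0.30 log units; within the scatter) from compound 3 to compound 4, 11-fold (1.05 log units) apart, beyond the scatter of two such steps

The added methyl on the core, within the scatter in the earlier pair, now gives a 17-fold higher number from compound 2 to compound 4 (1.22 log units; beyond the scatter) with the ethoxy group in place: the same change on two cores in this assay, a 1.5-fold higher number (0.17 log units; within the scatter) from compound 1 to compound 3 and a 17-fold higher number (1.22 log units; beyond the scatter) from compound 2 to compound 4, 11-fold (1.05 log units) apart, beyond the scatter of two such steps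

Across these four compounds the two changes therefore do not add, and neither can be read apart from the other.

The compounds shown leave open whether this dependence extends to other groups at the same place, such as a propoxy chain or a dimethylamino group. They also leave open whether a chlorine in place of the core methyl would behave the same way.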